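This account rests on a few compounds, and the source may have more. Where it says the series, first, only, none or still open, it means among the compounds named here.

Measured compounds in an ADME assay on cells (Splenocyte, Mus musculus, strain BALB/c) for cytotoxicity, read by CCK-8 assay, with a stated time of 48 h; a lower number here means that less compound is tolerated, a higher number that more compound is tolerated: compound 1 `CCc1ccc(-c2noc(Cc3c[nH]c4ccccc34)n2)cc1` gives 24400 nM; compound 2 `COc1cc(-c2noc(-c3ccc(NC(=O)OC(C)(C)C)cc3)n2)cc(OC)c1OC` gives 9200 nM; compound 3 `COc1cc(-c2noc(C3CC4(C3)CC(F)(F)C4)n2)cc(OC)c1OC` gives 28500 nM.

Among these three, compound 2 stands lowest in this assay: compound 1 gives a higher number, beyond the scatter, and compound 3 a higher number still, also beyond the scatter. Compound 4 `CCCCc1ccc(-c2nc(-c3cc(OC)c(OC)c(OC)c3)no2)cc1` has not been measured in this assay. It differs from compound 2 in one place: butyl in place of (tert-butoxycarbonyl)amino on an aromatic carbon. Going by the values given here, no two measured compounds differ in just one place, so no step of this kind has been seen directly. A modest upward step in this assay is expected, moving compound 4 toward the two better-tolerated compounds. Compound 4 is estimated at 16000 nM, with a range from 6000 nM to 45000 nM. This corresponds to an expected step of a 1.7-fold higher number from compound 2 to compound 4 (0.24 log units; within the scatter).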

Compound 4, half-maximal cytotoxic concentration: 21200 nM
For compound 4 the middle estimate is 1.3-fold (0.12 log units) below the measured one, within the range that was stated.
By their numbers in this assay, from the lowest: compound 2; then compounds 4, 1 and 3 (each within the scatter of the next).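

In this assay, putting butyl in place of (tert-butoxycarbonyl)amino on this aromatic carbon, para to a large group, gives the first step seen directly at this position: a 2.3-fold higher number from compound 2 to compound 4 (0.36 log units; beyond the scatter). The entering group is smaller than the one it replaces and has no hydrogen-bond donors or acceptors, and the step is modest but lies beyond the scatter. No measurement available here accounts for this step. From the compounds shown here alone, it remains open whether an amine or a carboxylic acid at this position would stay nearer compound 2 or compound 4, and whether a longer chain would extend the step.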